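Triazole series on the shared core: toward compound 3

This account rests on a few compounds, and the source may have more. Where it says the series, first, only, none or still open, it means among the compounds named here.

Measured so far:
compound 1, `O=C1O[C@H]([C@@H](O)Cn2cc(-c3cc(F)cc(F)c3)nn2)C(OCc2ccccc2)=C1OCc1ccccc1`: 27700 nM
compound 2, `O=C1O/C(=C\Cn2cc(-c3cccc(O)c3)nn2)C(OCc2ccccc2)=C1OCc1ccccc1`: 27800 nM

In a functional assay on MCF7 cells (Homo sapiens) for antiproliferative activity, read by MTT assay, with a stated time of 72 h (a higher number here means a weaker inhibitor, a lower number a stronger inhibitor), compound 1 gives 27700 nM; compound 2 gives 27800 nM, and the two values lie within the scatter of each other, so neither stands apart. Compound 3, `O=C1O[C@H]([C@@H](O)Cn2cc(CNS(=O)(=O)c3ccc(Cl)cc3)nn2)C(OCc2ccccc2)=C1OCc1ccccc1`, is not yet measured in this assay. It differs from compound 1 as follows: (((4-chlorophenyl)sulfonyl)amino)methyl in place of 3,5-difluorophenyl on an aromatic carbon. Among the measured compounds shown here, no measured pair shows what such a change does to the numbers. The expectation is for no step beyond the scatter, as a 1.1-fold higher number from compound 1 to compound 3 (0.03 log units; within the scatter), and for compound 3 a value of 30000 nM is estimated, between 8000 nM and 100000 nM.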

Compound 3, half-maximal inhibitory concentration: 4170 nM
For compound 3 the middle estimate is 7.2-fold (0.86 log units) above the measured one; measured number outside the range, below it.
By their numbers in this assay, from the lowest: compound 3; then compounds 1 and 2 (each within the scatter of the next).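

At the aromatic carbon of the five-membered ring with 3 nitrogen, the group held there can shift the number in this assay: (((4-chlorophenyl)sulfonyl)amino)methyl in place of 3,5-difluorophenyl gives a 6.6-fold lower number from compound 1 to compound 3 (0.82 log units; beyond the scatter) on the same core. The swap keeps one six-membered aromatic ring but adds a sulfonyl, an amino hydrogen-bond donor and a methylene link, so this single step cannot assign the gain to any one of them. No measurement at hand accounts for the step.

Open, from the compounds shown here alone, is which part carries the step: a plain aminomethyl group or a carboxylic acid on that carbon would begin to separate the link from the 4-chlorophenyl ring.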